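Benzyl to Butyl on the Chain of Compound 3

The compounds below may be only part of what the source reports. "The series", "measured", "known", "first", "only" and "open" are said of these compounds alone.

Measured compounds:
compound 1, `O=[N+]([O-])c1cccc(COCNc2n[n+]([O-])c3ccccc3[n+]2[O-])c1`, gives 5650 nM in a functional assay on K562 cells (Homo sapiens) for cytotoxicity, read by MTT assay, with a stated time of 72 h; on this read-out lower numbers stand for stronger inhibition and higher numbers for weaker inhibition
compound 2, `COc1ccc2c(c1)[n+]([O-])nc(NCOCc1ccccc1)[n+]2[O-]`, gives 27500 nM in this assay
compound 3, `[O-][n+]1nc(NCOCc2ccccc2)[n+]([O-])c2ccccc21`, gives 16100 nM in this assay

Compound 3 holds the second highest of the three numbers. Its nearest neighbour is compound 2: the step of a 1.7-fold lower number from compound 2 to compound 3 (0.23 log units; within the scatter) stays within the scatter, so the two are not told apart. The step of a 2.8-fold higher number from compound 1 to compound 3 (0.45 log units; beyond the scatter) is modest but beyond the scatter, and it is the only clear movement among the three.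

Compound 4, `CCCCOCNc1n[n+]([O-])c2ccccc2[n+]1[O-]`, is compound 3 with propyl in place of phenyl on a saturated chain carbon bound to an oxygen on a saturated carbon. Neither measured step bears directly on this change: both keep the phenyl and vary a group on an aromatic carbon, one on the phenyl and one on the shared core. The step of a 2.8-fold higher number from compound 1 to compound 3 (0.45 log units; beyond the scatter) shows that what sits on the phenyl can move the number, yet it says nothing about removing the phenyl itself. For the measured compounds named here, with no step of the same kind to lean on, the expectation for compound 4 is an uncertain one: a step of a 1.6-fold higher number from compound 3 to compound 4 (0.19 log units; within the scatter) is estimated, tilted toward a higher number, and a number beyond the scatter is not assured. Compound 4 is therefore expected to give about 25000 nM, within a range of 8000 nM to 80000 nM.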

Compound 4, half-maximal inhibitory concentration: 17600 nM
The estimate for compound 4 lay 1.4-fold (0.15 log units) above the measured number, and the stated range covers the measured number.
By their numbers in this assay, from the lowest: compound 1; then compounds 3, 4 and 2 (each within the scatter of the next).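

In this assay, putting propyl in place of phenyl on a saturated chain carbon bound to an oxygen on a saturated carbon gives a 1.1-fold higher number from compound 3 to compound 4 (0.04 log units; within the scatter) and so leaves the two compounds not told apart. For the compounds shown here, the earlier compounds all kept the phenyl and varied only groups on aromatic carbons, so this pair is the first to test the ring itself, and here, read the other way as benzyl to butyl, the six-membered aromatic ring of carbon only can leave without a change that this read-out can distinguish. The data offer no account of why the number holds once the ring has gone.

Going by these compounds, whether a longer chain, a branched chain or an amine at the end of the chain would hold the number as butyl does remains open. So does whether the clear step seen with the nitro group on the phenyl of compound 1 has any counterpart on a chain that carries no ring, such as a nitro group or a carboxylic acid placed on the butyl.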